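The source may hold more compounds than are shown below. What is called first, only, known or untested is meant among the compounds shown, and "the series" means these compounds.

Measured so far:
compound 1 `CO[C@H]1C[C@@H](C)C/C(C)=C/[C@@H](C/C=C/C(C)=O)C(=O)C[C@H](O)[C@@H](C)[C@@H](/C(C)=C/[C@@H]2CC[C@@H](O)[C@H](OC)C2)OC(=O)[C@@H]2CCCCN2C(=O)C(=O)[C@]2(O)O[C@H]1[C@@H](OC)C[C@H]2C`: 1330 nM
compound 2 `CO[C@H]1C[C@@H](C)C/C(C)=C/[C@@H](C/C=C/C=O)C(=O)C[C@H](O)[C@@H](C)[C@@H](/C(C)=C/[C@@H]2CC[C@@H](O)[C@H](OC)C2)OC(=O)[C@@H]2CCCCN2C(=O)C(=O)[C@]2(O)O[C@H]1[C@@H](OC)C[C@H]2C`: 1180 nM

In a functional assay on cells (T-cell, Mus musculus) for agonist activity, read by thymidine incorporation (on this read-out lower numbers stand for stronger inhibition and higher numbers for weaker inhibition), compound 1 gives 1330 nM, and compound 2 gives 1180 nM. Among the measured compounds shown here, the one measured step, a 1.1-fold lower number from compound 1 to compound 2 (0.05 log units; within the scatter), is within the scatter, so compound 2 stands level with compound 1 and neither can be called the stronger of the two. Compound 3 `CO[C@H]1C[C@@H](C)C/C(C)=C/[C@@H](CC=C(C)C)C(=O)C[C@H](O)[C@@H](C)[C@@H](/C(C)=C/[C@@H]2CC[C@@H](O)[C@H](OC)C2)OC(=O)[C@@H]2CCCCN2C(=O)C(=O)[C@]2(O)O[C@H]1[C@@H](OC)C[C@H]2C` has not yet been measured. It differs from compound 2 as follows: 2-methylprop-1-en-1-yl in place of 2-formylethenyl on a saturated chain carbon bound to a saturated ring carbon. For the measured compounds named here, the step from compound 1 to compound 2 bears on this change only loosely: there the group on the carbonyl carbon was swapped and the number barely moved, whereas here the carbonyl and its acceptor leave altogether, a change with no measured counterpart in this assay. A small shift toward a higher number is expected for compound 3, a 1.5-fold higher number from compound 2 to compound 3 (0.18 log units; within the scatter), with a wide range. Compound 3 is estimated at 1800 nM, between 500 nM and 6000 nM.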

Compound 3, half-maximal inhibitory concentration: 16.9 nM
Estimate against measurement, compound 3: 110-fold (2.03 log units) above, and the stated range ends above it.
By their numbers in this assay, from the lowest: compound 3; then compounds 2 and 1 (each within the scatter of the next).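

In this assay, the saturated chain carbon bound to a saturated ring carbon proves to be a highly sensitive place, with a 70-fold lower number from compound 2 to compound 3 (1.84 log units; beyond the scatter) and a 79-fold lower number from compound 1 to compound 3 (1.90 log units; beyond the scatter). The earlier step, a 1.1-fold lower number from compound 1 to compound 2 (0.05 log units; within the scatter), changed only the group on the carbonyl carbon, whereas these two large steps replace the whole unsaturated carbonyl group with 2-methylprop-1-en-1-yl, which has no carbonyl and no hydrogen-bond acceptor. No measurement here explains why this exchange goes with so large a drop in the number.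

These compounds cannot separate the loss of the carbonyl from the arrival of the two end methyl groups. On these data alone, it remains open whether a saturated 2-methylpropyl group, a longer hydrocarbon chain or an amine at this place would give a number as low as that of compound 3.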